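The compounds below may be only part of what the source reports. "The series", "measured", "known", "first", "only" and "open" are said of these compounds alone.

In a functional assay on MCF7 cells (Homo sapiens) for cytotoxicity, read by sulforhodamine B assay, with a stated time of 48 h (a lower number here means a stronger inhibitor, a higher number a weaker inhibitor), compound 1 `CC(=O)N(C(C)=O)C1=C(C#N)C(c2ccc(F)cc2)C2=C(CC(C)(C)CC2=O)N1c1ccc(S(N)(=O)=O)cc1` gives 79700 nM. Compound 2 `CC1(C)CC(=O)C2=C(C1)N(c1ccc(S(N)(=O)=O)cc1)C(N)=C(C1=NCCN1)C2c1ccc(F)cc1` gives 87000 nM in this assay, a number within the scatter of the first, so the two cannot be ranked against each other. Compound 3 `CC(=O)CC(=O)NC1=C(C#N)C(c2ccc(F)cc2)C2=C(CC(C)(C)CC2=O)N1c1ccc(S(N)(=O)=O)cc1` has not yet been measured; it differs from compound 1 in one place: ((2-oxopropyl)carbonyl)amino in place of diacetylamino on a double-bonded ring carbon. Within the data shown here, no step between measured compounds is on hand to guide the prediction, and the atoms are the same, only joined differently, so a step of a 1.0-fold higher number from compound 1 to compound 3 (0.00 log units; within the scatter) is expected, nothing beyond the scatter. The estimate for compound 3 is 80000 nM, with a range from 35000 nM to 180000 nM.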

Compound 3, half-maximal inhibitory concentration: > 100000 nM
Compound 3: only a limit was reported; the forecaster's own chance of this, stated with the estimate: 15%; middle value at least 1.2-fold (0.09 log units) away from the limit.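

In this assay compound 3 gives > 100000 nM, which is a limit of the assay and not a number. Putting ((2-oxopropyl)carbonyl)amino in place of diacetylamino rearranges the same atoms and adds a hydrogen-bond donor, and it gives an at least 1.2-fold higher number from compound 1 to compound 3 (0.09 log units; that floor lies within the scatter), so only a floor is known and it does not separate the two compounds. The true size of the change at this position therefore stays unread: the limit of > 100000 nM in this assay, at which 1 of the 3 values shown sits.

As far as these compounds go, whether a carboxylic acid or a longer chain at this place on the shared core would give a clearly lower number in this assay remains open.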